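The source may report more compounds than this note shows. Statements on the series, on what has been measured and on what is new or still open speak of the compounds shown alone.

Of the compounds shown here, two that share a core have been measured so far in an in vivo ADME assay on the whole organism (plasma) for pharmacokinetics, with Rattus norvegicus as the target, at a dose of 5 mg/kg by the intravenous route; a higher number here means faster removal of the compound, a lower number slower removal. Compound 1 `CC(=O)c1cccc(CC[C@H](SC[C@@H](C)C(=O)O)c2cccc(/C=C/c3ccc4ccc(Cl)cc4n3)c2)c1` gives 2 mL/min/kg, and compound 2 `C[C@H](CS[C@@H](CCc1cccc(CO)c1)c1cccc(/C=C/c2ccc3ccc(Cl)cc3n2)c1)C(=O)O` gives 2.5 mL/min/kg. Compound 1 thus has a single neighbour on this scale, and the two numbers cannot be told apart. These compounds differ in one place, with hydroxymethyl in place of acetyl on an aromatic carbon. Compound 3 `COC(=O)c1cccc(CC[C@H](SC[C@@H](C)C(=O)O)c2cccc(/C=C/c3ccc4ccc(Cl)cc4n3)c2)c1` alters the acetyl of compound 1 in another way, with methoxy in place of methyl on a carbonyl carbon. This turns acetyl into methoxycarbonyl and leaves the rest of the structure untouched. For the measured compounds named here, only one measured step bears on this change, and it is a different replacement of the same acetyl. Since the step of a 1.3-fold higher number from compound 1 to compound 2 (0.10 log units; within the scatter) stayed within the scatter, no clear shift is expected in this assay here either. Going by the values given here, the evidence is thin, as no measured compound carries methoxycarbonyl. The expected step of a 1.3-fold higher number from compound 1 to compound 3 (0.10 log units; within the scatter) therefore has no firm direction and is not expected to exceed the scatter. For compound 3 the estimated clearance is 2.5 mL/min/kg, with an expected range from 1.2 mL/min/kg to 6 mL/min/kg.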

Compound 3, clearance: 6 mL/min/kg
Compound 3: the middle estimate sits 2.4-fold (0.38 log units) below what was measured; low and high end bracket the measured number.
By their numbers in this assay, from the lowest: compounds 1 and 2 (each within the scatter of the next); then compound 3.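

In this assay, the group on this aromatic carbon can shift the number after all: methoxycarbonyl in place of acetyl gives a 3.0-fold higher number from compound 1 to compound 3 (0.48 log units; beyond the scatter), and methoxycarbonyl in place of hydroxymethyl gives a 2.4-fold higher number from compound 2 to compound 3 (0.38 log units; beyond the scatter). Acetyl and hydroxymethyl lay within the scatter of each other, so the earlier pair gave no sign that this position mattered, whereas compound 3 shows that replacing the methyl on the carbonyl carbon with methoxy, a small edit that leaves the rest of the structure untouched, is enough for a modest but readable rise in clearance. Nothing measured for these compounds gives a reason for this rise.

The compounds shown leave open how other groups on this aromatic carbon would behave, for example a carboxylic acid or an amide in place of the methoxycarbonyl, and so whether the rise is particular to methoxycarbonyl. They also leave open whether the same replacement would produce a step of similar size on a different core, as this change is seen here on the shared core alone.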